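The source may hold more compounds than are shown below. What is called first, only, known or untested is meant among the compounds shown, and "the series" means these compounds.

Measured in a functional assay on HepG2 cells (Homo sapiens) for inhibition, read by MTT assay, with a stated time of 48 h; on this read-out lower numbers stand for stronger inhibition of growth and higher numbers for weaker inhibition of growth:
Compound 1 `Cn1cc(C2CC(c3ccccc3)=NN2C(=O)c2ccc(Cl)nc2)c2ccccc21`: 7910 nM
Compound 2 `Cc1ccc(C(=O)N2N=C(c3ccccc3)CC2c2cn(C)c3ccccc23)cn1`: 1220 nM
Compound 3 `Cn1cc(C2CC(c3ccc(F)cc3)=NN2C(=O)c2cccnc2)c2cc(Br)ccc21`: 480 nM

Compound 3, at 480 nM, has the lowest number of the three. Compound 4 `Cn1cc(C2CC(c3ccc(Br)cc3)=NN2C(=O)c2cccnc2)c2cc(Br)ccc21` differs from compound 3 in one place: bromo in place of fluoro on an aromatic carbon, para to a large group (bromo in place of fluoro on an aromatic carbon). For the measured compounds named here, the only measured step, a 6.5-fold lower number from compound 1 to compound 2 (0.81 log units; beyond the scatter), put methyl in place of chloro on an aromatic carbon at another place, and this modest step lies beyond the scatter. Going by the values given here, a single small swap can therefore matter, but no measured pair tests this one, and the data give no direction for it. The estimated change is a 1.1-fold lower number from compound 3 to compound 4 (0.03 log units; within the scatter), which is expected to stay within the scatter. For compound 4 the estimated value is 450 nM, with an expected range of 150 nM to 1300 nM.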

Compound 4, concentration for 50% growth inhibition: 6910 nM
Estimate against measurement, compound 4: 15-fold (1.19 log units) below, outside the stated range (above it).
By their numbers in this assay, from the lowest: compound 3; then compound 2; then compounds 4 and 1 (each within the scatter of the next).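

In this assay, for the compounds shown here, changing 4-fluorophenyl to 4-bromophenyl gives a 14-fold higher number from compound 3 to compound 4 (1.16 log units; beyond the scatter) and this is the first measured step at this position. It shows that the position is sensitive: swapping one halogen for another, with no change in rings, hydrogen-bond donors, hydrogen-bond acceptors or net charge, is enough to produce a large step. Still open, going by these compounds, is how an amine or a methoxy group on this same carbon would compare with fluoro and bromo. Nothing available here gives a reason for the size of this step.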